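A few compounds are considered here, and "the series" means these few. Any claim that something is new, unique, unknown or untested is made for them only; others in the source may bear on it.

Measured so far:
Compound 1 `N=C(S)CCCn1nc(-c2ccccc2)ccc1=O` gives 75.6% in a functional assay on the whole organism (stomach) for inhibition, with Rattus norvegicus as the target, at a dose of 100 mg/kg by the intraduodenal route; on this read-out higher numbers stand for more inhibition at the one dose given (going by the name of the read-out) and lower numbers for less inhibition.
Compound 2 `Cc1cc(=O)n(CCC(=N)S)nc1-c1ccccc1` gives 32% in this assay.
Compound 3 `N=C(S)CCCCCCN1N=C(c2ccccc2)CCC1=O` gives 68.3% in this assay.

Among these three numbers compound 3 stands second highest. Its nearest neighbour is compound 1, whose reading lies within the scatter of it, so no order between the two can be drawn; compound 2 lies beyond the scatter, below compound 3. Compound 4 `N=C(S)CCCCN1N=C(c2ccccc2)CCC1=O` has not yet been measured. It differs from compound 3 in one place: a group of 3 heavy atoms (1 carbon, 1 nitrogen, 1 sulfur; no ring) in place of a group of 5 heavy atoms (3 carbon, 1 nitrogen, 1 sulfur; no ring), on a saturated chain carbon, four bonds along the chain from an amide-type nitrogen in a ring. For the measured compounds named here, no measured pair shows this step, so the expectation rests on the three readings alone. Compound 1 and compound 3 give numbers within the scatter of each other. Hence the expected step is a number 1.7 percentage points higher from compound 3 to compound 4 (within the scatter), nothing beyond the scatter. Compound 4 is expected to give 70% in this assay, within 50% to 88%.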

Compound 4, a percentage reported as inhibition, in the whole organism at one dose (the size of the read-out at that dose, not a potency): 50.2%
The estimate for compound 4 lay 19.8 percentage points above the measured number, and the stated range covers the measured number.
By their numbers in this assay, from the lowest: compound 2; then compound 4; then compounds 3 and 1 (each within the scatter of the next).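

In this assay, the group of 3 heavy atoms in place of the group of 5 heavy atoms, on a saturated chain carbon, gives a number 18.1 percentage points lower from compound 3 to compound 4 (beyond the scatter) on an otherwise unchanged structure. This shows that the reading at this position depends on chain length, since the shorter chain alone moves it beyond the scatter. No measurement at hand accounts for this step. From the compounds shown here alone, whether a longer chain than that of compound 3 would hold the reading remains open, as does whether an amine or a carboxylic acid in place of this group would retain any inhibition.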